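The source may hold more compounds than are shown below. What is called first, only, known or untested is meant among the compounds shown, and "the series" means these compounds.

Measured compounds:
compound 1 `COc1cc(C2=NOC(c3c[nH]c4ccccc34)C2)cc(OC)c1OC`: 15500 nM
compound 2 `Clc1ccc(Cn2cc(C3CC(c4ccncc4)=NO3)c3ccccc32)cc1`: 25700 nM
compound 3 `COc1ccc2c(c1)c(C1CC(c3ccncc3)=NO1)cn2Cc1ccc(Cl)cc1`: 55200 nM

In a functional assay on PC-3 cells (Homo sapiens) for inhibition, read by MTT assay, with a stated time of 48 h (on this read-out higher numbers stand for weaker inhibition and lower numbers for stronger inhibition), compound 1 has the smallest of the three numbers, but compound 2 lies within the scatter of it, so the two are not separated; only compound 3 stands apart, beyond the scatter. Within the data shown here, the single one-place step measured so far is a 2.1-fold higher number from compound 2 to compound 3 (0.33 log units; beyond the scatter), methoxy in place of hydrogen on an aromatic carbon of the core, a modest change. Compound 4 `COc1ccc(C2=NOC(c3c[nH]c4ccccc34)C2)cc1OC` differs from compound 1 by hydrogen in place of methoxy on an aromatic carbon. That is the reverse kind of change, but on a different ring, so the measured step bears on it only loosely; no step beyond the scatter is expected, and the direction is open. For compound 4 the estimated value is 15000 nM (range 6000 nM to 40000 nM), meaning an expected step of a 1.0-fold lower number from compound 1 to compound 4 (0.01 log units; within the scatter).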

Compound 4, half-maximal inhibitory concentration: 70100 nM
Compound 4: the middle estimate sits 4.7-fold (0.67 log units) below what was measured, outside the stated range (above it).
By their numbers in this assay, from the lowest: compounds 1 and 2 (each within the scatter of the next); then compounds 3 and 4 (each within the scatter of the next).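

On the core of compound 1, the methoxy on the aromatic carbon ortho to a methoxy group counts: hydrogen in its place weakens inhibition in this assay (a 4.5-fold higher number from compound 1 to compound 4 (0.66 log units; beyond the scatter)). The same exchange therefore has no single direction in this series, with methoxy going with stronger inhibition on the core of compound 1 and weaker inhibition on the core of compound 2: the same change on two cores in this assay, a 2.1-fold higher number (0.33 log units; beyond the scatter) from compound 2 to compound 3 and a 4.5-fold lower number (0.66 log units; beyond the scatter) from compound 4 to compound 1, 9.7-fold (0.99 log units) apart, beyond the scatter of two such steps.

Open, going by these compounds, is whether this carbon needs methoxy itself or accepts another group. A hydroxyl, a fluorine or an ethoxy group there would separate these cases.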